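A few compounds are considered here, and "the series" means these few. Any claim that something is new, unique, unknown or untested is made for them only; others in the source may bear on it.

Compound 1 `COc1ccc(S(C)(=O)=O)c(NCC2=NCCN2)c1` belongs to a small set that includes compound 2 `CSc1cc(F)ccc1NCC1=NCCN1` and compound 3 `COc1ccc(SC)c(NCC2=NCCN2)c1`. In a functional assay for agonist activity at Alpha-1B adrenergic receptor (Homo sapiens) (a lower number here means that less compound is needed, a higher number that more compound is needed for the effect), compound 1 gives only a limit, < 100000 nM. In this assay compound 2 gives 6.03 nM, and compound 3 gives 3.63 nM. For the measured compounds named here, the only measured step that touches compound 1 is a step that the limit leaves unreadable from compound 1 to compound 3, which cannot be sized because of the limit of < 100000 nM in this assay, at which 1 of the 3 values shown sits. Going by the values given here, the new compound 4 `CS(=O)(=O)c1ccc(Cl)cc1NCC1=NCCN1` differs from compound 1 by chloro in place of methoxy on an aromatic carbon, a change none of the measured pairs shows, while the methylsulfonyl group of compound 1 stays. Compound 4 is therefore expected to remain weak, with a step that the limit leaves unreadable from compound 1 to compound 4 carrying little weight. The value of compound 4 in this assay is estimated at 10000 nM, within 500 nM to 100000 nM.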

Compound 4, half-maximal effective concentration: 61.7 nM
Beside the measured number, compound 4's estimate is 160-fold (2.21 log units) above it, outside the stated range (below it).
By their numbers in this assay, from the lowest: compounds 3 and 2 (each within the scatter of the next); then compound 4.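

For the compounds shown here, no step from compound 1 to compound 4 can be read, as compound 1 gives only a limit: the limit of < 100000 nM in this assay, at which 1 of the 4 values shown sits. The compounds shown leave open how far chloro in place of methoxy alone shifts the value in this assay.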